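Permeability notes: oxadiazolyl-cyclobutyl replacement in the sulfonamide series

This account rests on a few compounds, and the source may have more. Where it says the series, first, only, none or still open, it means among the compounds named here.

Measured so far in an ADME assay on MDCKII-LE cells (Canis lupus familiaris) for permeability; on this read-out higher numbers stand for higher permeability and lower numbers for lower permeability:
- compound 1 `N#C[C@H]1C[C@@H]1CN([C@H](CCC(F)(F)F)C(N)=O)S(=O)(=O)c1ccc(Cl)cc1`: 21.5 10^-6 cm/s
- compound 2 `N#C[C@H]1CC[C@H](CN([C@H](CCC(F)(F)F)C(N)=O)S(=O)(=O)c2ccc(Cl)cc2)CC1`: 15.7 10^-6 cm/s; 14.6 10^-6 cm/s (2 entries)

Within the data shown here, compound 1 is the only compound here with a single number in this assay; compound 2 has several entries, and these are gathered as the several entries of compound 2 in this assay, 15.7 10^-6 cm/s; 14.6 10^-6 cm/s (2 entries). Among the measured compounds shown here, no step between the two is worked out; their values show that compound 1 and compound 2 lie within the usual scatter of each other, so no order between them is claimed.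

The step followed here goes from compound 1 to compound 3 `NC(=O)[C@@H](CCC(F)(F)F)N(C[C@H]1C[C@@H](c2ncon2)C1)S(=O)(=O)c1ccc(Cl)cc1`, which is not yet measured in this assay. The change is 3-(1,2,4-oxadiazol-3-yl)cyclobutyl in place of 2-cyanocyclopropyl on a saturated chain carbon bound to a sulfonamide nitrogen. The group that enters is larger than the one that leaves and carries more hydrogen-bond acceptors, as counted above. Nothing measured in the series bears on such a change, so no cause can be pointed to.

The expectation is a modest shift, if any beyond the scatter, towards lower permeability: the step from compound 1 to compound 3 is estimated as a 1.5-fold lower number from compound 1 to compound 3 (0.19 log units; within the scatter). For compound 3 the estimated value in this assay is 14 10^-6 cm/s, with a range from 7 10^-6 cm/s to 28 10^-6 cm/s.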

Compound 3, apparent permeability: 14.1 10^-6 cm/s
The estimate for compound 3 lay 1.0-fold (0.00 log units) below the measured number; the range from low to high includes it.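

In this assay, 3-(1,2,4-oxadiazol-3-yl)cyclobutyl replaces 2-cyanocyclopropyl on a saturated chain carbon bound to a sulfonamide nitrogen with a 1.5-fold lower number from compound 1 to compound 3 (0.18 log units; within the scatter), so no order between the two compounds is claimed. Among these compounds, this is the first step read at this place, and it shows that a larger group with more hydrogen-bond acceptors and an aromatic ring in place of the nitrile can stand there without a change beyond the scatter. Compound 3 also gives a number of the same size as a third group at this place, one that keeps a nitrile on a larger ring of carbon: the several entries of compound 2 in this assay, 15.7 10^-6 cm/s; 14.6 10^-6 cm/s (2 entries)

The step changes the ring of carbon and the nitrile together, so the compounds shown cannot separate the two, and they give no cause for the values. Whether this place stays as tolerant with a primary amine or a carboxylic acid on the cyclobutyl ring also remains open, as neither group appears among these compounds.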